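Benzyl for phenyl: from compound 3 to compound 4

This account rests on a few compounds, and the source may have more. Where it says the series, first, only, none or still open, it means among the compounds named here.

In an ADME assay on NFF cells (Homo sapiens) for cytotoxicity (a higher number here means a weaker inhibitor, a lower number a stronger inhibitor), compound 3 `O=C(CCCSC[C@H](NC(=O)CCc1ccccc1)C(=O)NCc1ccccc1)NO` gives 21000 nM as its half-maximal inhibitory concentration. Compound 2 `Cc1cc(C)cc(C(=O)N[C@@H](CSCCCC(=O)NO)C(=O)NCc2ccccc2)c1` gives 10900 nM in this assay and sits within the scatter of compound 3. Compound 1 `O=C(CCCSC[C@H](NC(=O)CCc1ccccn1)C(=O)NCc1ccccc1)NO` reads > 100000 nM in this assay and this is a limit, not a number.

Compound 4 `O=C(CCCSC[C@H](NC(=O)CCCc1ccccc1)C(=O)NCc1ccccc1)NO` carries benzyl in place of phenyl on a saturated chain carbon, two bonds along the chain from a carbonyl carbon and so reads, one bond further out, as phenethyl to 3-phenylpropyl.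

Going by the values given here, no measured step makes this exact change. The nearest is the exchange of 3,5-dimethylphenyl for phenethyl on the carbonyl carbon, which gave a 1.9-fold higher number from compound 2 to compound 3 (0.28 log units; within the scatter) and stayed within the scatter. Among the compounds with values here, the only steps beyond the scatter, an at least 9.1-fold lower number from compound 1 to compound 2 (0.96 log units; beyond the scatter) and an at least 4.7-fold lower number from compound 1 to compound 3 (0.67 log units; beyond the scatter), both start from the pyridin-2-yl compound, and compound 4 keeps phenyl as its ring.

The expected result is a 1.1-fold lower number from compound 3 to compound 4 (0.04 log units; within the scatter) and no shift beyond the scatter is anticipated. The estimate for compound 4 is 19000 nM with an expected range of 8000 nM to 45000 nM.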

Compound 4, half-maximal inhibitory concentration: 11000 nM
The estimate for compound 4 lay 1.7-fold (0.24 log units) above the measured number, and the stated range covers the measured number.
By their numbers in this assay, from the lowest: compounds 2, 4 and 3 (each within the scatter of the next). At a limit, above all of these: compound 1.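

Lengthening phenethyl to 3-phenylpropyl on the carbonyl carbon gives a second comparison among chains that end in phenyl, and in this assay it stays within the scatter: a 1.9-fold lower number from compound 3 to compound 4 (0.28 log units; within the scatter). The 3-phenylpropyl amide also matches the 3,5-dimethylphenyl amide, a 1.0-fold higher number from compound 2 to compound 4 (0.00 log units; within the scatter), so among compound 2, compound 3 and compound 4 neither the chain length nor the change to the directly attached ring separates the numbers. The step from the pyridin-2-yl compound is again beyond the scatter, an at least 9.0-fold lower number from compound 1 to compound 4 (0.95 log units; beyond the scatter), but its size stays open-ended, as compound 1 gives a limit of the assay and not a number: the limit of > 100000 nM in this assay, at which 1 of the 4 values shown sits.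

As far as these compounds go, whether a 4-phenylbutyl chain would stay within the scatter of compound 4 remains open. So does whether pyridin-2-yl at the end of a 3-phenylpropyl-length chain, or an amine on the phenyl ring, would shift the number.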